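Reversing the amide: from benzylamide to cyclopropanecarboxamide

A few compounds are considered here, and "the series" means these few. Any claim that something is new, unique, unknown or untested is made for them only; others in the source may bear on it.

The series is built on a shared core with a chloro-substituted pyridine, a methylpiperazine and a piperidine. Among the compounds with values here, in a functional assay for antagonist activity at C-X-C chemokine receptor type 3 (Homo sapiens) (a higher number here means a weaker inhibitor, a lower number a stronger inhibitor), compound 1 `CNC(=O)c1cnc(N2CCN(C3CCN(C(F)(F)F)CC3)[C@@H](C)C2)c(Cl)c1` gives 63 nM and compound 2 `CNC(=O)c1cnc(N2CCN(C3CCN(Cc4ccc(Cl)cc4F)CC3)[C@@H](C)C2)c(Cl)c1` gives 18 nM; the step of a 3.5-fold lower number from compound 1 to compound 2 (0.54 log units; beyond the scatter) is the only single change measured directly. Compound 3 `C[C@H]1CN(c2ncc(C(=O)NCc3ccc(F)c(F)c3)cc2Cl)CCN1C1CCN(Cc2ccc(Cl)cc2)CC1` gives 6 nM in this assay, the lowest of the three numbers, with compound 2 and compound 1 both beyond the scatter above it; compound 2 and compound 3 differ in more than one place, so their values show only that the larger benzylamide with the 4-chlorobenzyl pairs with the lower number.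

Compound 4 `C[C@H]1CN(c2ncc(NC(=O)C3CC3)cc2Cl)CCN1C1CCN(Cc2ccc(Cl)cc2)CC1` carries (cyclopropylcarbonyl)amino in place of (3,4-difluorobenzyl)carbamoyl on an aromatic carbon. Within the data shown here, no measured step touches this position, and the benzyl substituent on the piperidine, where the only measured step lies, is unchanged. Compound 2 shows that a small amide still gives a low number, so the author expects a modest rise, a 5.0-fold higher number from compound 3 to compound 4 (0.70 log units; beyond the scatter). Compound 4 is therefore estimated at 30 nM, with a range from 8 nM to 120 nM.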

Compound 4, half-maximal inhibitory concentration: 20 nM
Beside the measured number, compound 4's estimate is 1.5-fold (0.18 log units) above it, and the stated range covers the measured number.
By their numbers in this assay, from the lowest: compound 3; then compounds 2 and 4 (each within the scatter of the next); then compound 1.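

Within the data shown here, this is the first measured change at this position: with the 4-chlorobenzyl group on the piperidine held fixed, (cyclopropylcarbonyl)amino in place of (3,4-difluorobenzyl)carbamoyl gives a modest rise in this assay (a 3.3-fold higher number from compound 3 to compound 4 (0.52 log units; beyond the scatter)). The step is beyond the scatter, yet it is modest even though the change removes the six-membered aromatic ring and turns the amide around, so the benzyl ring is not required for a number of this order. These two alterations arrive as one step and cannot be separated, and nothing available explains the rise.

Open, as far as these compounds go, is whether the reversed amide carrying a 3,4-difluorobenzyl group would match compound 3. Also open, from the compounds shown here alone, is how a plain acetyl amide, a cyclohexanecarboxamide or a methanesulfonamide at this position would compare with the cyclopropanecarboxamide.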